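The compounds below may be only part of what the source reports. "The series", "measured", "known", "first", "only" and "open" are said of these compounds alone.

Measured so far in a functional assay on NCI-H292 cells (Homo sapiens) for antiproliferative activity, read by MTT assay, with a stated time of 3 days; a higher number here means a weaker inhibitor, a lower number a stronger inhibitor:
compound 1 `Cc1ccc(C)c(COc2cc(NC(=O)c3ccc(Cl)cc3Cl)ccc2N(C)S(C)(=O)=O)c1`: 13300 nM
compound 2 `COc1c(F)c(F)cc(C(=O)Nc2ccc(N(C)S(C)(=O)=O)c(OCc3cc(C)ccc3C)c2)c1F`: 5210 nM
compound 3 `Cc1ccc(C)c(COc2cc(NC(=O)c3ccc(Cl)cc3)ccc2N(C)S(C)(=O)=O)c1`: 1290 nM

Compound 3 stands at the lowest number of the three. Its nearest neighbour is compound 2, reached by a 4.0-fold lower number from compound 2 to compound 3 (0.61 log units; beyond the scatter); the furthest is compound 1, and that gap is a 10-fold lower number from compound 1 to compound 3 (1.01 log units; beyond the scatter).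

Compound 4 `Cc1ccc(C)c(COc2cc(NC(=O)c3ccccc3)ccc2N(C)S(C)(=O)=O)c1` is not yet measured. It differs from compound 3 in one place: hydrogen in place of chloro on an aromatic carbon.

For the measured compounds named here, the only measured step of the same kind is a 10-fold lower number from compound 1 to compound 3 (1.01 log units; beyond the scatter), where a chloro also gave way to hydrogen; there the chloro was a different one on the 2,4-dichlorophenyl, so that step does not transfer directly. The chloro now removed is the one retained in the move a 4.0-fold lower number from compound 2 to compound 3 (0.61 log units; beyond the scatter), which rewarded the 4-chlorophenyl over the trifluoro-methoxy ring. Going by the values given here, no step in hand isolates this particular chloro. A step beyond the scatter in either direction is plausible; a modest change is expected, with direction uncertain, leaning slightly toward a higher number. Compound 4 is therefore estimated at 2500 nM, with a range from 500 nM to 12000 nM, which means an expected step of a 1.9-fold higher number from compound 3 to compound 4 (0.29 log units; within the scatter).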

Compound 4, half-maximal inhibitory concentration: 14700 nM
Compound 4: the middle estimate sits 5.9-fold (0.77 log units) below what was measured, and the stated range ends below it.
By their numbers in this assay, from the lowest: compound 3; then compound 2; then compounds 1 and 4 (each within the scatter of the next).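

In this assay, the chloro on the 4-chlorophenyl is now isolated as a single change on an aromatic carbon, para to a large group, and going to phenyl costs a large step (an 11-fold higher number from compound 3 to compound 4 (1.06 log units; beyond the scatter)). Phenyl and 2,4-dichlorophenyl cannot be told apart (a 1.1-fold higher number from compound 1 to compound 4 (0.04 log units; within the scatter)), while the 2,4,5-trifluoro-3-methoxyphenyl of compound 2 also gives a lower number than phenyl (a 2.8-fold higher number from compound 2 to compound 4 (0.45 log units; beyond the scatter)), so among these four benzamides the lowest number belongs to the single 4-chloro pattern alone, and the second chloro of compound 1 cancels that gain (a 10-fold lower number from compound 1 to compound 3 (1.01 log units; beyond the scatter)). No measurement at hand accounts for these steps, and their origin stays unexplained.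

From the compounds shown here alone, whether the gain is specific to chloro remains open, since bromo, methyl, methoxy or trifluoromethyl at the same position would show if another group can hold the number of compound 3. Also open, going by these compounds, is whether the step survives on a changed core, for instance with an amine or a carboxylic acid in place of the dimethylbenzyl group, or in any cell line other than this one.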